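Methylsulfanyl to sulfanyl on a para-methoxybenzylamino analogue

The source may report more compounds than this note shows. Statements on the series, on what has been measured and on what is new or still open speak of the compounds shown alone.

Measured compounds in a functional assay on HT-29 cells (Homo sapiens) for cytotoxicity, read by MTT assay, with a stated time of 72 h; on this read-out higher numbers stand for weaker inhibition of growth and lower numbers for stronger inhibition of growth:
compound 1 `Sc1nc(NCc2ccccc2)c2ccccc2n1` gives 10100 nM
compound 2 `CSc1nc(NCc2ccccc2)c2ccccc2n1` gives 36500 nM
compound 3 `COc1ccc(CNc2nc(SC)nc3ccccc23)cc1` gives 70200 nM

Compound 2 carries a methylsulfanyl group on the shared core; compound 1 is its sulfanyl counterpart. The difference is hydrogen in place of methyl on a sulfur. On this read-out the step is a 3.6-fold lower number from compound 2 to compound 1 (0.56 log units; beyond the scatter).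

Compound 3 differs from compound 2 in the benzyl part, by methoxy in place of hydrogen on an aromatic carbon. Its step is a 1.9-fold higher number from compound 2 to compound 3 (0.28 log units; within the scatter), so compound 2 and compound 3 cannot be separated on this assay.

Compound 4 `COc1ccc(CNc2nc(S)nc3ccccc23)cc1` is not yet measured. It is related to compound 3 by hydrogen in place of methyl on a sulfur. The surroundings of the sulfur are described in the same words for compound 2 and compound 3, so this is the same change as that from compound 2 to compound 1, now made on the core that carries the methoxy group.

Among the compounds with values here, for compound 4 the step expected from compound 3 is a 3.6-fold lower number from compound 3 to compound 4 (0.56 log units; beyond the scatter), taken to match the measured step of a 3.6-fold lower number from compound 2 to compound 1 (0.56 log units; beyond the scatter), since that is the only precedent for the change in this set. The transfer of the step rests on one pair only, and compound 3 itself sits within the scatter of compound 2, so the expected number is held with a wide range. Compound 4 is estimated at 19500 nM, between 8000 nM and 45000 nM.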

Compound 4, concentration for 50% growth inhibition: 6490 nM
Compound 4: middle estimate off by 3.0-fold (0.48 log units), on the high side, and the stated range ends above it.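

In this assay, hydrogen in place of methyl on a sulfur gives an 11-fold lower number from compound 3 to compound 4 (1.03 log units; beyond the scatter) on the core that carries the methoxy group, so the direction of the step carries over from the core of compound 2, but its size does not: the same change on two cores in this assay, a 3.6-fold lower number (0.56 log units; beyond the scatter) from compound 2 to compound 1 and an 11-fold lower number (1.03 log units; beyond the scatter) from compound 3 to compound 4, 3.0-fold (0.48 log units) apart, beyond the scatter of two such steps. Methoxy in place of hydrogen on an aromatic carbon gives a 1.6-fold lower number from compound 1 to compound 4 (0.19 log units; within the scatter), so compound 1 and compound 4 cannot be separated on this read-out, yet the methoxy steps on the two cores still stand apart from each other: the same change on two cores in this assay, a 1.9-fold higher number (0.28 log units; within the scatter) from compound 2 to compound 3 and a 1.6-fold lower number (0.19 log units; within the scatter) from compound 1 to compound 4, 3.0-fold (0.48 log units) apart, beyond the scatter of two such steps. Two pairs show that the step from methylsulfanyl to sulfanyl lowers the number on both cores and that its size cannot be assumed constant, but they establish no general rule and do not show why the size differs.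

Going by these compounds, it remains open whether the same direction holds with a longer chain on the sulfur, such as ethyl, or with an amine in place of the sulfur group. Also open, on these data alone, is how the step behaves when the benzyl part carries a group other than methoxy, such as chlorine or a carboxylic acid, and whether the gap between the two steps recurs on such cores.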